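Replacing the remaining methyl of compound 2

The compounds below may be only part of what the source reports. "The series", "measured", "known", "first", "only" and "open" are said of these compounds alone.

In a functional assay on the whole organism with Canis familiaris (Canis lupus familiaris) as the target (on this read-out higher numbers stand for an effect only at larger amounts of compound and lower numbers for an effect already at smaller amounts), compound 1 `Cc1ccc(-c2nc3cc[nH]cc-3n2)c(C)c1` gives 1.4 mg/kg and compound 2 `COc1cc(C)ccc1-c1nc2cc[nH]cc-2n1` gives 0.28 mg/kg, so compound 2 holds the lower of the two numbers. The next compound is compound 3 `COc1cc(OS(C)(=O)=O)ccc1-c1nc2cc[nH]cc-2n1`, which carries (methylsulfonyl)oxy in place of methyl on an aromatic carbon, para to a group of 9 heavy atoms: (methylsulfonyl)oxy in place of methyl on an aromatic carbon. Among the compounds with values here, only one measured step bears on this change, and only loosely: a 5.0-fold lower number from compound 1 to compound 2 (0.70 log units; beyond the scatter), with methoxy in place of methyl. Within the data shown here, the methyl leaving now is not the one exchanged in that step, and the entering group has no measured precedent. That step therefore sets only a rough scale. In this assay, no shift clearly beyond the scatter is expected, with a slight lean towards a higher number. The expected step is a 1.6-fold higher number from compound 2 to compound 3 (0.21 log units; within the scatter). The estimate for compound 3 is 0.45 mg/kg, with an expected range of 0.12 mg/kg to 1.7 mg/kg.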

Compound 3, dose for half-maximal effect: 0.006 mg/kg
Estimate against measurement, compound 3: 75-fold (1.88 log units) above; the whole stated range lies above it.
By their numbers in this assay, from the lowest: compound 3; then compound 2; then compound 1.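

In this assay, the aromatic carbon para to a group of 9 heavy atoms accepts far more than a methyl: with (methylsulfonyl)oxy, 5 heavy atoms and 3 hydrogen-bond acceptors in place of 1 heavy atom and none, the series shows a 47-fold lower number from compound 2 to compound 3 (1.67 log units; beyond the scatter). Within the data shown here, this is the first measured change at this position, and it is a large step towards effect at smaller doses, so this carbon is a sensitive point, at least with the methoxy group retained. No measurement at hand accounts for the size of this step.

On these data alone, with only methyl and (methylsulfonyl)oxy compared at this position, it remains open whether the bridging oxygen or the methylsulfonyl part carries the step. A methylsulfonyl bonded directly to the ring, an amine or a longer chain such as ethylsulfonyloxy would help to separate these possibilities.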